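Cyclopropylmethyl in place of phenyl on the amide nitrogen

The compounds below may be only part of what the source reports. "The series", "measured", "known", "first", "only" and "open" are said of these compounds alone.

Of the compounds shown here, three built on one shared core have been measured in an assay on CHO-K1 cells for displacement of a labelled ligand from adenosine receptor A1 (Homo sapiens), with a stated time of 2 h; on this read-out lower numbers stand for stronger inhibition and higher numbers for weaker inhibition. Compound 1 `O=C(CCc1ccccc1)NCc1ccc2[nH]c(=O)c(-c3nccs3)c(CCc3ccccc3)c2c1` gives 3250 nM, compound 2 `Cc1cc(-c2c(CCc3ccccc3)c3cc(OCC(=O)NC(C)(C)c4ccccc4)ccc3[nH]c2=O)on1` gives 12 nM, and compound 3 `CS(=O)(=O)c1c(CCc2ccccc2)c2cc(OCC(=O)Nc3ccccc3)ccc2[nH]c1=O` gives 1330 nM. Compound 3 thus stands second highest of the three: compound 1 lies higher by a margin beyond the scatter, and compound 2 lies far lower, also beyond the scatter. Compound 4 `CS(=O)(=O)c1c(CCc2ccccc2)c2cc(OCC(=O)NCC3CC3)ccc2[nH]c1=O` differs from compound 3 in one place: cyclopropylmethyl in place of phenyl on an amide-type nitrogen. Among the measured compounds shown here, no pair of measured compounds isolates such a change, and compound 2 differs from compound 3 in more than one place, so its low number cannot be tied to the amide substituent alone. The step of a 2.2-fold lower number from compound 3 to compound 4 (0.35 log units; beyond the scatter) is expected to be modest and toward a lower number. Compound 4 is estimated at 600 nM, within 150 nM to 2500 nM.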

Compound 4, inhibition constant: > 10000 nM
Compound 4 ended at the assay's limit; the forecaster's own chance of this, stated with the estimate: 5%; at least 16-fold (1.22 log units) between middle value and limit.
By their numbers in this assay, from the lowest: compound 2; then compound 3; then compound 1. At a limit, above all of these: compound 4.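

In this assay compound 4 gives > 10000 nM, which is a limit of the assay and not a number. On the amide-type nitrogen, cyclopropylmethyl in place of phenyl gives an at least 7.5-fold higher number from compound 3 to compound 4 (0.87 log units; beyond the scatter), the first step isolated at this position, and it runs toward weaker inhibition. The size of that step is only a bound: the limit of > 10000 nM in this assay, at which 1 of the 4 values shown sits.

The compounds shown leave open whether a benzyl group or a plain methyl on this nitrogen would stay near the value of compound 3. They also leave open whether the phenyl ring itself or its direct attachment to the nitrogen counts.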